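Swapping the Chloromethyl Handle for a Vinyl Group

The compounds below may be only part of what the source reports. "The series", "measured", "known", "first", "only" and "open" are said of these compounds alone.

Among the compounds with values here, compound 1 `O=C(CCl)Nc1ccc(SCC(=O)Nc2cc(Cl)ccn2)cc1` is the only member of the set with a numerical result: in a functional assay on HeLa cells (Homo sapiens) for antiproliferative activity, read by MTT assay, with a stated time of 48 h (a higher number here means a weaker inhibitor, a lower number a stronger inhibitor), compound 1 gives 2800 nM. Compound 2 `O=C(CCl)Nc1ccc(SCC(=O)Nc2cccc(Cl)c2)cc1` reaches only a limit, > 80000 nM. Compound 3 `O=C(CCl)Nc1ccc(SCC(=O)Nc2ccc(Cl)cc2)cc1` likewise reaches only a limit, > 80000 nM. Compound 1 therefore stands apart because of the limit of > 80000 nM in this assay, at which 2 of the 3 values shown sit. The steps of an at least 28-fold higher number from compound 1 to compound 2 (1.45 log units; beyond the scatter) and an at least 28-fold higher number from compound 1 to compound 3 (1.45 log units; beyond the scatter) both alter the group on the amide-type nitrogen, while a step that the two limits leave unreadable from compound 2 to compound 3 cannot be sized. Compound 4 `C=CC(=O)Nc1ccc(SCC(=O)Nc2cc(Cl)ccn2)cc1` changes a different position: vinyl in place of chloromethyl on a carbonyl carbon. Within the data shown here, none of the measured steps touches this carbonyl substituent, so they give no direct guide. Resting only on the closeness of the two structures, a modest loss is estimated, a 1.8-fold higher number from compound 1 to compound 4 (0.25 log units; within the scatter). Compound 4 is estimated at 5000 nM, within a range from 1500 nM to 25000 nM.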

Compound 4, half-maximal inhibitory concentration: 25200 nM
For compound 4 the middle estimate is 5.0-fold (0.70 log units) below the measured one; the whole stated range lies below it.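

In this assay, within the data shown here, the carbonyl substituent proves to matter: vinyl in place of chloromethyl on a carbonyl carbon brings a 9.0-fold higher number from compound 1 to compound 4 (0.95 log units; beyond the scatter), the first reading at this position. The earlier steps shown here changed only the group on the amide-type nitrogen, and compound 4 still gives a number rather than a limit. Nothing shown accounts for this step.

Going by these compounds, whether a methyl, an ethyl or a bromomethyl group on this carbonyl would read closer to compound 1 or compound 4 stays open. So does whether this change would read alike with 3-chlorophenyl or 4-chlorophenyl on the amide-type nitrogen.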